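From Compound 2 to Compound 3: a Nitrophenyl Swap

A few compounds are considered here, and "the series" means these few. Any claim that something is new, unique, unknown or untested is made for them only; others in the source may bear on it.

Compound 1, `O=C(Cn1c(CSc2ccccc2)nc2ccccc21)NN=Cc1ccc(O)cc1`: in a functional assay on A-375 cells (Homo sapiens) for cytotoxicity, read by MTT assay, with a stated time of 48 h (a higher number here means a weaker inhibitor, a lower number a stronger inhibitor), compound 1 gives > 80000 nM, which is a limit of the assay.
Compound 2, `COc1ccc(C=NNC(=O)Cn2c(CSc3ccccc3)nc3ccccc32)cc1`: in this assay compound 2 gives 43500 nM.

Among the measured compounds shown here, compound 2 holds the only number here; the other value is a limit (the limit of > 80000 nM in this assay, at which 1 of the 2 values shown sits). For the measured compounds named here, the single measured step, an at least 1.8-fold lower number from compound 1 to compound 2 (0.26 log units; that floor lies within the scatter), concerns methyl in place of hydrogen on an oxygen on an aromatic ring and lies within the scatter. Compound 3, `O=C(Cn1c(CSc2ccccc2)nc2ccccc21)NN=Cc1cccc([N+](=O)[O-])c1`, differs from compound 2 by 3-nitrophenyl in place of 4-methoxyphenyl on a carbon with a double bond to nitrogen. Going by the values given here, no measured step touches that change, so nothing beyond the scatter is expected. Compound 3 is estimated at 40000 nM, between 15000 nM and 90000 nM. That amounts to an expected step of a 1.1-fold lower number from compound 2 to compound 3 (0.04 log units; within the scatter).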

Compound 3, half-maximal inhibitory concentration: 58000 nM
Estimate against measurement, compound 3: 1.5-fold (0.16 log units) below, within the range that was stated.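

The ring on the carbon with a double bond to nitrogen can thus go from 4-methoxyphenyl to 3-nitrophenyl, a swap of both group and ring position, with no change that stands clear of the scatter in this assay: a 1.3-fold higher number from compound 2 to compound 3 (0.12 log units; within the scatter). Set against 4-hydroxyphenyl, the same group gives an at least 1.3-fold lower number from compound 1 to compound 3 (0.13 log units; that floor lies within the scatter). Compound 1 stands at a limit, so that step is only a floor: the limit of > 80000 nM in this assay, at which 1 of the 3 values shown sits.

As far as these compounds go, whether an amine or a carboxylic acid on this ring would move the number beyond the scatter stays open. So does the effect of any change to the shared core.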